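The source may hold more compounds than are shown below. What is called first, only, known or untested is meant among the compounds shown, and "the series" means these compounds.

Measured compounds:
- compound 1, `CCN(CC)S(=O)(=O)c1ccc(S(=O)(=O)N2CCC[C@@H](C(=O)N[C@H]3CC[C@H](OC)CC3)C2)cc1`: 2290 nM
- compound 2, `CCN(CC)S(=O)(=O)c1ccc(S(=O)(=O)N2CCC[C@@H](C(=O)N3CCC(OC)CC3)C2)cc1`: 50 nM
- compound 3, `CC(C)S(=O)(=O)c1ccc(S(=O)(=O)N2CCC[C@@H](C(=O)N3CCC(F)(F)CC3)C2)cc1`: 9.1 nM

In a functional assay on MIA PaCa-2 cells (Homo sapiens) for inhibition, read by MTT assay, with a stated time of 3 days (a higher number here means a weaker inhibitor, a lower number a stronger inhibitor), compound 2 stands second highest of the three numbers: compound 3 lies well below it, and compound 1 lies far above it. Compound 4, `CCN(CC)S(=O)(=O)c1ccc(S(=O)(=O)N2CCC[C@@H](C(=O)NC3CCOCC3)C2)cc1`, is not yet measured. It differs from compound 2 in one place: (oxan-4-yl)amino in place of 4-methoxypiperidin-1-yl on a carbonyl carbon. The same kind of change, in the opposite direction, has already been seen between compound 1 and compound 2, where a (4-methoxycyclohexyl)amino group on the carbonyl carbon was replaced by 4-methoxypiperidin-1-yl: a 46-fold lower number from compound 1 to compound 2 (1.66 log units; beyond the scatter). Compound 4 moves back to an amino-linked ring on the carbonyl carbon, as in compound 1, so a step of comparable size toward a higher number is expected in this assay. Compound 4 is therefore estimated at 1500 nM, within a range from 400 nM to 6000 nM. This estimate means a step of a 30-fold higher number from compound 2 to compound 4 (1.48 log units; beyond the scatter), which is expected to lie well beyond the scatter.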

Compound 4, half-maximal inhibitory concentration: 1350 nM
The estimate for compound 4 lay 1.1-fold (0.05 log units) above the measured number; the measured number falls inside the stated range.
By their numbers in this assay, from the lowest: compound 3; then compound 2; then compounds 4 and 1 (each within the scatter of the next).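

The change on the carbonyl carbon from 4-methoxypiperidin-1-yl to (oxan-4-yl)amino gives a 27-fold higher number from compound 2 to compound 4 (1.43 log units; beyond the scatter) in this assay and counts as a large step. Changing only the ring on the amide-type nitrogen, oxan-4-yl in place of 4-methoxycyclohexyl, gives a 1.7-fold lower number from compound 1 to compound 4 (0.23 log units; within the scatter) in this assay and so cannot be told apart from no change. Among these compounds, the large gap therefore follows the switch between a piperidin-1-yl attachment and an amino attachment, and a second ring on the amino side does not alter that picture.

Still open, from the compounds shown here alone, is whether the amide hydrogen itself matters, which a methyl group in its place on the (oxan-4-yl)amino compound could separate from the change in ring attachment. No supporting measurement explains the gap.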